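This account rests on a few compounds, and the source may have more. Where it says the series, first, only, none or still open, it means among the compounds named here.

Compound 1, `COc1cc(SC)nc(NC(=S)NC(=O)c2c(-c3ccc(Cl)cc3Cl)noc2C)n1`, and compound 2, `COc1cc(SC)nc2n/c(=N/C(=O)c3c(-c4ccc(Cl)cc4Cl)noc3C)sn12`, were both tested in a functional assay on the whole organism for inhibition, with Chenopodium ficifolium as the target, with a stated time of 72 h, tested at 100 mg/L; on this read-out higher numbers stand for more inhibition of growth at the one concentration tested and lower numbers for less inhibition of growth. In this assay compound 1 gives 60.3%, and compound 2 gives 68.3%. Compound 1 thus stands with the lower of the two numbers, yet the gap to compound 2 lies within the usual scatter, so the two are not told apart on this read-out.

Compound 3, `COc1cc(C)nc(NC(=S)NC(=O)c2c(-c3ccc(Cl)cc3Cl)noc2C)n1`, has not been measured in this assay. It differs from compound 1 in one place: methyl in place of methylsulfanyl on an aromatic carbon. Among the measured compounds shown here, no step between measured compounds is available to show what such a change does to growth inhibition here, and the two values known differ only within the scatter. Compound 3 is therefore expected to give about 57%, within the range 40% to 74%. The step of a number 3.3 percentage points lower from compound 1 to compound 3 (within the scatter) is estimated to be small, in no direction beyond the scatter.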

Compound 3, percent growth inhibition at one concentration: 59.8%
Compound 3: the middle estimate sits 2.8 percentage points below what was measured; measured number inside the range.
By their numbers in this assay, from the lowest: compounds 3, 1 and 2 (each within the scatter of the next).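

Among the compounds shown here, the change from methylsulfanyl to methyl on this aromatic carbon provides the only step in this assay between compounds that differ in one place, and it reads a number 0.5 percentage points lower from compound 1 to compound 3 (within the scatter) within this account. At the one concentration tested, replacing methylsulfanyl with methyl here leaves no difference that can be told from the scatter, so the sulfur atom is not shown to be needed for growth inhibition. Nothing available on these compounds accounts for this result.

The compounds shown leave open whether a group of another kind on this carbon, such as an amine, a chlorine atom or a longer chain, would move growth inhibition beyond the scatter. They also leave open whether the same change would read the same way on the core of compound 2.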